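The source may report more compounds than this note shows. Statements on the series, on what has been measured and on what is new or still open speak of the compounds shown alone.

Compound 1 `COc1ccc(-c2cc3c(cn2)[nH]c(=O)n3-c2cc(OC)c(OC)c(OC)c2)cc1F`: 2020 nM
Compound 2 `COc1ccc(-c2cc3c(cn2)[nH]c(=O)n3-c2cc(OC)c(OC)c(OC)c2)cn1`: 1220 nM
Compound 3 `CCOc1ccc(-c2cc3c(cn2)[nH]c(=O)n3-c2cc(OC)c(OC)c(OC)c2)cc1F`: 2540 nM
Compound 4 `COc1ccc(-c2cc3c(cn2)[nH]c(=O)n3-c2cc(OC)c(OC)c(OC)c2)cc1N`: not yet measured

In a functional assay on A549 cells (Homo sapiens) for antiproliferative activity, read by MTT assay, with a stated time of 48 h (a higher number here means a weaker inhibitor, a lower number a stronger inhibitor), compound 3 gives 2540 nM. That cannot be told apart from compound 1, as a 1.3-fold higher number from compound 1 to compound 3 (0.10 log units; within the scatter) shows, whereas a 2.1-fold higher number from compound 2 to compound 3 (0.32 log units; beyond the scatter) separates it modestly from compound 2.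

Compound 4 brings a new group: 3-amino-4-methoxyphenyl in place of 4-ethoxy-3-fluorophenyl on an aromatic carbon. In words, 3-amino-4-methoxyphenyl replaces 4-ethoxy-3-fluorophenyl on an aromatic carbon. Changes at this place have been small so far, with a 1.7-fold lower number from compound 1 to compound 2 (0.22 log units; within the scatter) as a further example. For the measured compounds named here, no measured compound carries the amino group, so its effect remains open, and the range must be wide. A modest drop is expected, a 2.5-fold lower number from compound 3 to compound 4 (0.40 log units; beyond the scatter). For compound 4 the estimated value is 1000 nM, with an expected range of 150 nM to 3000 nM.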

Compound 4, half-maximal inhibitory concentration: 1140 nM
Beside the measured number, compound 4's estimate is 1.1-fold (0.06 log units) below it, and the stated range covers the measured number.
By their numbers in this assay, from the lowest: compounds 4, 2, 1 and 3 (each within the scatter of the next, the first and the last beyond it).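

In this assay, putting amino in place of fluoro on the aryl group leaves the number within the scatter (a 1.8-fold lower number from compound 1 to compound 4 (0.25 log units; within the scatter)), so this single swap has no readable effect. Compound 4 also cannot be told apart from the 6-methoxypyridin-3-yl compound (a 1.1-fold lower number from compound 2 to compound 4 (0.03 log units; within the scatter)). Only the exchange for 4-ethoxy-3-fluorophenyl separates, modestly, with the amino compound the stronger inhibitor (a 2.2-fold lower number from compound 3 to compound 4 (0.35 log units; beyond the scatter)). From the compounds shown here alone, whether an acetamide or a hydroxyl in place of the amino group would shift the number remains open. Nothing at hand explains any of these steps.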